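A few compounds are considered here, and "the series" means these few. Any claim that something is new, unique, unknown or untested is made for them only; others in the source may bear on it.

Compound 1, `O=c1c(-c2nn[nH]n2)c[nH]c2c(Cl)c(Cl)ccc12`, in a functional assay on the whole organism (strain Sprague-Dawley) for inhibition, with Rattus norvegicus as the target; on this read-out higher numbers stand for an effect only at larger amounts of compound and lower numbers for an effect already at smaller amounts: a limit, > 0.156 mg/kg.
Compound 2, `O=c1c(-c2nn[nH]n2)c[nH]c2ccccc12`: 1.25 mg/kg in this assay.
Compound 3, `O=c1c(-c2nn[nH]n2)c[nH]c2c(Cl)cc(Cl)cc12`: a limit, > 0.156 mg/kg in this assay.

Compound 3 stands only at a limit, not at a number: in this assay compound 3 gives > 0.156 mg/kg. This is the same limit at which compound 1 sits, and the account of the data notes (the limit of > 0.156 mg/kg in this assay, at which 2 of the 3 values shown sit). Going by the values given here, the only number in the set belongs to compound 2, which in this assay gives 1.25 mg/kg. Among the compounds with values here, no step between two measured compounds differing in one place is available, so the size of any step is open.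

Compound 4, `O=c1c(-c2nn[nH]n2)c[nH]c2c(Cl)cccc12`, differs from compound 3 by hydrogen in place of chloro on an aromatic carbon. Compound 4 thus keeps one chloro where compound 3 carries two and compound 2 carries none. With compound 3 at a limit and compound 2 at a number, the expected step that the limit leaves unreadable from compound 3 to compound 4 in this assay is toward a measurable minimum effective dose, beyond the scatter. Compound 4 is therefore estimated to give 0.8 mg/kg in this assay, expected between 0.25 mg/kg and 4 mg/kg.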

Compound 4, minimum effective dose: 0.078 mg/kg
Estimate against measurement, compound 4: 10-fold (1.01 log units) above; the measured number lies below the stated range.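

Going by these compounds alone, with chloro in place of hydrogen on an aromatic carbon, a 16-fold lower number from compound 2 to compound 4 (1.20 log units; beyond the scatter), so a single chloro on the shared core has a large effect in this assay, which no earlier pair could show. With hydrogen in place of the other chloro, the two dichloro compounds give an at least 2.0-fold lower number from compound 3 to compound 4 (0.30 log units; that floor lies within the scatter) and an at least 2.0-fold lower number from compound 1 to compound 4 (0.30 log units; that floor lies within the scatter), and neither floor lies beyond the scatter. These two steps therefore do not show that losing the second chloro changes the dose, and both rest on limits rather than numbers: the limit of > 0.156 mg/kg in this assay, at which 2 of the 4 values shown sit.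

Going by these compounds, how far the second chloro truly moves the dose, in either of its two places, stays open while compound 1 and compound 3 stand only at limits. On these data alone, whether a fluoro or a methoxy group at the chloro position of compound 4 would keep the step from compound 2 is also open.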